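The source may report more compounds than this note shows. Statements on the series, on what has been measured and on what is new or still open speak of the compounds shown alone.

Compound 2 `Cc1nc(-c2cccnc2)sc1-c1nnc(-c2ccc(O)cc2)o1` is the parent of this step; in an ADME assay on HCT-116 cells (Homo sapiens) for cytotoxicity, read by MTT assay (a lower number here means that less compound is tolerated, a higher number that more compound is tolerated), compound 2 gives > 100 ug/mL, which is a limit of the assay and not a number. Compound 1 `Cc1nc(-c2cccnc2)sc1-c1nnc(-c2cccc(Cl)c2Cl)o1` is the one comparator, and in this assay compound 1 gives > 100 ug/mL, again a limit. The step that the two limits leave unreadable from compound 1 to compound 2 is thus unreadable; both values rest on (the limit of > 100 ug/mL in this assay, at which 2 of the 2 values shown sit). Compound 3 `Cc1nc(-c2cccnc2)sc1-c1nnc(-c2cccnc2)o1` carries pyridin-3-yl in place of 4-hydroxyphenyl on an aromatic carbon. Among the measured compounds shown here, no measured step gives a readable size for such a change, so no shift beyond the scatter is expected. Compound 3 is therefore expected at 100 ug/mL, within 50 ug/mL to 200 ug/mL. The expected step is a number no higher from compound 2 to compound 3 (the limit leaves the size open).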

Compound 3, half-maximal cytotoxic concentration: > 100 ug/mL
Compound 3 was reported as a limit (the forecaster's own chance of this, stated with the estimate: 80%); the middle value sits exactly at the limit.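

No step among compound 1, compound 2 and compound 3 can be read, since each value is a limit and not a number: the limit of > 100 ug/mL in this assay, at which 3 of the 3 values shown sit.

Going by these compounds, whether the tolerated concentrations of these three compounds differ at all remains open.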